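Chloro on the Benzyl Arm of Two Dihydropyrimidine Amides

The source may report more compounds than this note shows. Statements on the series, on what has been measured and on what is new or still open speak of the compounds shown alone.

Compound 1 `CC1=C(C(=O)Nc2ccc(F)cc2)C(c2ccc([N+](=O)[O-])cc2)N=C(SCc2ccccc2)N1` gives 32.3% in a functional assay on the whole organism (artery, strain albino) with Rattus norvegicus as the target, with a stated time of 240 min, at a dose of 10 mg/kg by the oral route; a higher number here means more inhibition at the dose given (going by the name of the read-out), a lower number less inhibition. Compound 2 `CC1=C(C(=O)Nc2ccc(F)cc2)C(c2ccc([N+](=O)[O-])cc2)N=C(SCc2ccccc2Cl)N1` carries one change, (chloro in place of hydrogen on an aromatic carbon), and gives 15.9% in this assay, so that the step of a number 16.4 percentage points lower from compound 1 to compound 2 (beyond the scatter). Compound 3 `CC1=C(C(=O)Nc2ccc([N+](=O)[O-])cc2)C(c2ccc(Br)cc2)N=C(SCc2ccccc2)N1` belongs to a second core; the difference between the two cores is not broken down here. In this assay compound 3 gives 27.7%, which lies within the scatter of compound 1 and beyond it relative to compound 2. Compound 4 `CC1=C(C(=O)Nc2ccc([N+](=O)[O-])cc2)C(c2ccc(Br)cc2)N=C(SCc2ccccc2Cl)N1` has not yet been measured in this assay. Its relation to compound 3 is chloro in place of hydrogen on an aromatic carbon, the same change that separates compound 2 from compound 1. The expectation for compound 4 rests on that single precedent, because compound 1 to compound 2 showed a number 16.4 percentage points lower from compound 1 to compound 2 (beyond the scatter), and because, starting near compound 1, compound 3 gives 27.7%. Compound 4 is therefore expected to show a step of a number 13.7 percentage points lower from compound 3 to compound 4 (beyond the scatter) in this assay. The estimated inhibition for compound 4 is 14%, with the likely range from 3% to 26%.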

Compound 4, a percentage reported as inhibition, in the whole organism at one dose (the size of the read-out at that dose, not a potency): 15.4%
Compound 4: the middle estimate sits 1.4 percentage points below what was measured, within the range that was stated.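

In this assay, going from benzyl to 2-chlorobenzyl on the second core gives a number 12.3 percentage points lower from compound 3 to compound 4 (beyond the scatter). Set beside the same change on the first core, this step does not differ from the earlier one: the same change on two cores in this assay, a number 16.4 percentage points lower (beyond the scatter) from compound 1 to compound 2 and a number 12.3 percentage points lower (beyond the scatter) from compound 3 to compound 4, 4.1 percentage points apart, within the scatter of two such steps. Among the compounds shown here, this shows that the lower number carried over from the core of compound 1 to the core of compound 3 in this assay, at the one dose and time tested, but with only two pairs it does not show that the change would behave alike on any other core, and it gives no reason for the drop.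

The compounds shown leave open whether fluoro, methyl or methoxy in place of the chloro, or a longer chain in place of the benzyl group on the sulfur, would lower the number in the same way. They also leave open which of the several differences between the two cores, among them the bromo and nitro groups, matters for the level of inhibition.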